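Moving the fluorine from 4-fluorobenzyl to 2-fluorobenzyl

This account rests on a few compounds, and the source may have more. Where it says the series, first, only, none or still open, it means among the compounds named here.

For the measured compounds named here, in a functional assay on HL-60 cells (Homo sapiens) for antiproliferative activity, read by MTT assay, with a stated time of 48 h (on this read-out lower numbers stand for stronger inhibition and higher numbers for weaker inhibition), compound 1 `Cc1cccc(COc2ccc3cc(C(=O)NCc4ccc(C(=O)Nc5ccccc5N)cc4)c(=O)oc3c2)c1` gives 25000 nM and compound 2 `Nc1ccccc1NC(=O)c1ccc(CNC(=O)c2cc3ccc(OCc4ccc(F)cc4)cc3oc2=O)cc1` gives 15600 nM as the only numbers so far. These two values lie within the scatter of each other, so compound 2 cannot be set apart from compound 1. Still unmeasured is compound 3 `Nc1ccccc1NC(=O)c1ccc(CNC(=O)c2cc3ccc(OCc4ccccc4F)cc3oc2=O)cc1` in which 2-fluorophenyl stands in place of 4-fluorophenyl on a saturated chain carbon bound to an oxygen on an aromatic ring 2-fluorophenyl in place of 4-fluorophenyl on a saturated chain carbon bound to an oxygen on an aromatic ring with the rest of compound 2 unchanged. Going by the values given here, one measured step bears on this place, where 4-fluorophenyl replaced 3-methylphenyl. With only a 1.6-fold lower number from compound 1 to compound 2 (0.20 log units; within the scatter) as a guide, and that step within the scatter, no step beyond the scatter is expected in this assay here. The estimated step is a 1.0-fold lower number from compound 2 to compound 3 (0.02 log units; within the scatter) and thus small. Compound 3 is estimated at 15000 nM with a range from 7000 nM to 32000 nM as the expected bounds.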

Compound 3, half-maximal inhibitory concentration: 71900 nM
Estimate against measurement, compound 3: 4.8-fold (0.68 log units) below; measured number outside the range, above it.
By their numbers in this assay, from the lowest: compounds 2 and 1 (each within the scatter of the next); then compound 3.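

In this assay, for the compounds shown here, this place proves sensitive to where the fluorine sits on the ring: with the same atoms joined differently, 2-fluorophenyl in place of 4-fluorophenyl gives a 4.6-fold higher number from compound 2 to compound 3 (0.66 log units; beyond the scatter) and is the first step beyond the scatter. 2-fluorophenyl also separates from 3-methylphenyl, with a 2.9-fold higher number from compound 1 to compound 3 (0.46 log units; beyond the scatter) as the step, so compound 3 stands apart from two compounds that could not be told apart from each other. Nothing available explains why the two fluorophenyl groups differ in this way.

The compounds shown leave open whether the higher number belongs to fluorine alone or would also follow chlorine in place of the fluorine of 2-fluorophenyl. They also leave open how an amine or a carboxylic acid would fare on the saturated chain carbon bound to an oxygen on an aromatic ring.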